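This account rests on a few compounds, and the source may have more. Where it says the series, first, only, none or still open, it means among the compounds named here.

Compound 1 (`COc1ccccc1C(=O)NC(CC(=O)O)c1ccccc1`) | > 100000 nM
Compound 2 (`O=C(O)CC(NC(=O)c1c(Cl)cccc1Cl)c1ccccc1`) | > 100000 nM
Compound 3 (`O=C(O)CC(NS(=O)(=O)c1ccccc1)c1ccccc1`) | > 100000 nM

All of these results come from a functional assay on MDA-MB-231 cells (Homo sapiens) for antiproliferative activity, read by MTT assay, with a stated time of 24 h (a lower number here means a stronger inhibitor, a higher number a weaker inhibitor), and all are limits of the assay, not numbers. Compound 3 gives > 100000 nM there, and that is only a limit. The whole set sits at one point (the limit of > 100000 nM in this assay, at which 3 of the 3 values shown sit), so compound 3 cannot be ranked against compound 1 or compound 2. Among the compounds with values here, no two measured compounds differ in a single place, so the effect of one change in this assay has not yet been seen.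

Compound 4 (`O=C(O)CC(NS(=O)(=O)c1ccc(F)cc1)c1ccccc1`) differs from compound 3 by one change (fluoro in place of hydrogen on an aromatic carbon): fluoro in place of hydrogen on an aromatic carbon, para to a large group, so that phenyl becomes 4-fluorophenyl. The measurements so far give this change no direction. The expectation rests on compound 3 and its limit (> 100000 nM), so no step beyond the scatter is expected, and the assay may well report only a limit again. The estimated step is small (a step that the limit leaves unreadable from compound 3 to compound 4) and is expected to stay within the scatter. For compound 4 the estimated value is 120000 nM (expected range 40000 nM to 300000 nM).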

Compound 4, half-maximal inhibitory concentration: 88400 nM
Estimate against measurement, compound 4: 1.4-fold (0.13 log units) above, within the range that was stated.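

In this assay compound 4 is the first of the compounds shown to give a number rather than a limit, which places a 4-fluorophenyl group, with the fluoro para to a large group, on the readable part of the scale. The change from phenyl to 4-fluorophenyl gives an at least 1.1-fold lower number from compound 3 to compound 4 (0.05 log units; that floor lies within the scatter), so the data do not show that this single fluoro moves the value by more than the usual scatter. The true size of the step remains unreadable because compound 3 rests on a limit rather than a number, as do the other earlier compounds: the limit of > 100000 nM in this assay, at which 3 of the 4 values shown sit.

The compounds shown leave open whether chloro, methoxy or an amine on this same aromatic carbon would also give a number, and whether any such group can bring the value clearly below that of compound 4. They also leave open how the series would respond to a methyl ester or a tetrazole in place of the carboxylic acid, with the 4-fluorophenyl group kept unchanged.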